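The compounds below may be only part of what the source reports. "The series", "measured", "known", "first", "only" and "open" are said of these compounds alone.

Working notes on the series. Compound 1 is `COc1nc2ccccc2cc1/C=C/c1noc(-c2ccccc2)n1`, compound 2 is `COc1nc2ccccc2cc1/C=C/c1noc(-c2ccc(Br)cc2)n1` and compound 3 is `COc1ccccc1-c1nc(/C=C/c2cc3ccccc3nc2OC)no1`. In an ADME assay on HepG2 cells (Homo sapiens) for cytotoxicity, read by sulforhodamine B assay, with a stated time of 48 h (on this read-out higher numbers stand for lower toxicity in this test and lower numbers for higher toxicity in this test), compound 1 gives > 240000 nM, a limit of the assay. Compound 2 gives > 195000 nM, also a limit. Compound 3 gives > 220000 nM, again a limit. The steps a step that the two limits leave unreadable from compound 1 to compound 2, a step that the two limits leave unreadable from compound 1 to compound 3 and a step that the two limits leave unreadable from compound 2 to compound 3 therefore cannot be sized. Compound 3 thus stands at a limit, as do the other two values, at the limit of > 195000 nM in this assay, at which 1 of the 3 values shown sits, the limit of > 220000 nM in this assay, at which 1 of the 3 values shown sits, and (the limit of > 240000 nM in this assay, at which 1 of the 3 values shown sits). Compound 4 is `COc1nc2ccccc2cc1/C=C/c1noc(-c2cccc(C)c2)n1`; the change is 3-methylphenyl in place of 2-methoxyphenyl on an aromatic carbon. Among the measured compounds shown here, no measured step bears readably on it, and no compound so far reached a number, so no step beyond the scatter is expected. Compound 4 is expected at 200000 nM, between 100000 nM and 400000 nM, most likely once more a limit. The expected step is an at least 1.1-fold lower number from compound 3 to compound 4 (0.04 log units; that floor lies within the scatter).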

Compound 4, half-maximal cytotoxic concentration: > 230000 nM
Compound 4: a limit, no number; the forecaster's own chance of this, stated with the estimate: 85%; middle value at least 1.1-fold (0.06 log units) from the limit.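

Compound 4 is again a limit, so its steps from compound 1, compound 2 and compound 3 cannot be read. The compounds shown leave open at what concentration any of them becomes cytotoxic in this assay.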